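Swapping the alkyne-linked group on a second core

The source may hold more compounds than are shown below. What is called first, only, known or untested is meant among the compounds shown, and "the series" means these compounds.

In a functional assay on U-937 cells (Homo sapiens) for inhibition, read by MTT assay, with a stated time of 72 h (on this read-out higher numbers stand for weaker inhibition and lower numbers for stronger inhibition), compound 1 `Cc1ccc(-c2nc3ccc(N4CCN(C)CC4)cc3[nH]2)cc1C#Cc1cnc(NC2CC2)nc1` gives 191 nM. Compound 2 `Cc1ccc(-c2nc3ccc(N4CCN(C)CC4)cc3[nH]2)cc1C#Cc1cnc2cccnn12` differs only in the group on the triple-bonded carbon, and in this assay compound 2 gives 608 nM; the step of a 3.2-fold higher number from compound 1 to compound 2 (0.50 log units; beyond the scatter) is a modest weakening beyond the usual scatter. Compound 3 `Cc1ccc(C(=O)Nc2ccc3c(c2)C(F)(F)C[C@H]3N2CCN(C)CC2)cc1C#Cc1cnc(NC2CC2)nc1` keeps the 2-(cyclopropylamino)pyrimidin-5-yl group of compound 1 but on a different core, and in this assay compound 3 gives 465 nM, the second highest of the three numbers: it lies within the scatter of compound 2, while compound 1 gives a lower number. Compound 4 `Cc1ccc(C(=O)Nc2ccc3c(c2)C(F)(F)C[C@H]3N2CCN(C)CC2)cc1C#Cc1cnc2cccnn12` is to compound 3 what compound 2 is to compound 1: a group of 9 heavy atoms (6 carbon, 3 nitrogen; one five-membered aromatic ring with 2 hetero atoms, one six-membered aromatic ring with 2 hetero atoms) in place of a group of 10 heavy atoms (7 carbon, 3 nitrogen; one three-membered non-aromatic ring of carbon only, one six-membered aromatic ring with 2 hetero atoms), on a triple-bonded carbon. Going by the values given here, only one measured step bears on this change, the one from compound 1 to compound 2, which was modest and beyond the scatter. A weakening of similar size is therefore expected, as the step of a 3.0-fold higher number from compound 3 to compound 4 (0.48 log units; beyond the scatter). Compound 4 is estimated at 1400 nM, with a likely range from 600 nM to 3500 nM.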

Compound 4, half-maximal inhibitory concentration: > 1000 nM
Compound 4 ended at the assay's limit; the forecaster's own chance of this, stated with the estimate: 5%; the middle value lies beyond the limit too.
By their numbers in this assay, from the lowest: compound 1; then compounds 3 and 2 (each within the scatter of the next). At a limit, above all of these: compound 4.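

In this assay, compound 4 reads > 1000 nM, which is a limit of the assay and not a number. The step is therefore only a minimum, an at least 2.1-fold higher number from compound 3 to compound 4 (0.33 log units; beyond the scatter), but it lies beyond the scatter and shows that the swap on the triple-bonded carbon also weakens inhibition on the second core. Among the compounds shown, the 2-(cyclopropylamino)pyrimidin-5-yl group thus gives the lower number on both cores, and the direction of the change holds on each: the same change on two cores in this assay, a 3.2-fold higher number (0.50 log units; beyond the scatter) from compound 1 to compound 2 and an at least 2.1-fold higher number (0.33 log units; beyond the scatter) from compound 3 to compound 4; the limit leaves it open whether they differ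

On these data alone, how large the step truly is on this core stays open, since its reading stops at the limit: the limit of > 1000 nM in this assay, at which 1 of the 4 values shown sits. The leaving group counts one hydrogen-bond donor and the entering group none, so it also remains open whether a 2-methoxypyrimidin-5-yl group on the triple-bonded carbon would read like compound 3 or like compound 4.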